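Amide variation on the naphthalenesulfonamide series: alkyl to pyridyl

A few compounds are considered here, and "the series" means these few. Any claim that something is new, unique, unknown or untested is made for them only; others in the source may bear on it.

Three compounds of the series carry measurements in an in vitro functional assay on CHO/Galpha16 cells for antagonist activity at C-C chemokine receptor type 8 (Homo sapiens), read by FLIPR; on this read-out lower numbers stand for stronger inhibition and higher numbers for weaker inhibition. Compound 1 `CCCC(=O)N1CCC(NS(=O)(=O)c2ccc(NC(=O)c3cccc(C)c3)c3ccccc23)CC1` gives 5.1 nM. Compound 3 `CCCC(=O)N1CCC(NS(=O)(=O)c2ccc(NC(=O)c3ccc(F)cc3)c3ccccc23)CC1` gives 59.5 nM. Compound 2 `CCCC(=O)N1CCC(NS(=O)(=O)c2ccc(NC(=O)C(CC)CC)c3ccccc23)CC1` gives 639 nM, the highest of the three numbers; its nearest neighbour is compound 3 (an 11-fold lower number from compound 2 to compound 3 (1.03 log units; beyond the scatter)) and the furthest is compound 1 (a 130-fold higher number from compound 1 to compound 2 (2.10 log units; beyond the scatter)).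

Compound 4 `CCCC(=O)N1CCC(NS(=O)(=O)c2ccc(NC(=O)c3cccnc3)c3ccccc23)CC1` is not yet measured. The change from compound 2 is pyridin-3-yl in place of pentan-3-yl on a carbonyl carbon. The leaving group is the same one that leaves in the step to compound 3, and there the number fell by an 11-fold lower number from compound 2 to compound 3 (1.03 log units; beyond the scatter); the step from compound 1 to compound 2, in the reverse sense, brings in the same group with a rise of a 130-fold higher number from compound 1 to compound 2 (2.10 log units; beyond the scatter). Both steps replace the pentan-3-yl group by a six-membered aromatic ring and both lie well beyond the scatter. Within the data shown here, no measured pair shows a pyridin-3-yl group against a phenyl group, so the position of compound 4 relative to compound 1 and compound 3 is open.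

Compound 4 is therefore expected to move by an 18-fold lower number from compound 2 to compound 4 (1.26 log units; beyond the scatter), a large fall. The estimate for compound 4 is 35 nM, with a range of 8 nM to 160 nM.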

Compound 4, half-maximal inhibitory concentration: 885 nM
The estimate for compound 4 lay 25-fold (1.40 log units) below the measured number, outside the stated range (above it).
By their numbers in this assay, from the lowest: compound 1; then compound 3; then compounds 2 and 4 (each within the scatter of the next).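

In this assay a six-membered aromatic ring on the carbonyl carbon does not by itself lower the number: pyridin-3-yl in place of pentan-3-yl gives a 1.4-fold higher number from compound 2 to compound 4 (0.14 log units; within the scatter), whereas compound 1 and compound 3, with their substituted phenyl groups, both stand well below compound 2. The identity of the ring therefore matters at this position, as the other two steps show: a 15-fold higher number from compound 3 to compound 4 (1.17 log units; beyond the scatter) and a 170-fold higher number from compound 1 to compound 4 (2.24 log units; beyond the scatter), which leave compound 4 on the same level as the branched alkyl compound rather than with the other aromatic amides. The data shown contain no measurement that accounts for this result.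

The pyridin-3-yl group differs from 3-methylphenyl and 4-fluorophenyl both in its ring nitrogen and in lacking a ring substituent, so these compounds leave open which of the two differences carries the large steps. An unsubstituted phenyl group at the same carbonyl carbon would separate them, and a pyridin-4-yl group or a methyl-bearing pyridin-3-yl group would show whether the placing of the nitrogen or an added methyl changes the outcome.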